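Swapping cyclohexyl for bromo: estimating compound 4

The source may report more compounds than this note shows. Statements on the series, on what has been measured and on what is new or still open speak of the compounds shown alone.

Three measured compounds share one core and differ only in the group attached to an aromatic carbon of a six-membered aromatic ring of carbon only. Compound 1 `CCCCCc1ccc(NS(=O)(=O)c2ccc(N3CCNC3=O)cc2)cc1` carries pentyl, and in a functional assay on M21 cells (Homo sapiens) for antiproliferative activity, read by sulforhodamine B assay, with a stated time of 48 h (a lower number here means a stronger inhibitor, a higher number a weaker inhibitor), compound 1 gives 870 nM. Compound 2 `COc1ccc(NS(=O)(=O)c2ccc(N3CCNC3=O)cc2)cc1` carries methoxy, and in this assay compound 2 gives 580 nM. Compound 3 `O=C1NCCN1c1ccc(S(=O)(=O)Nc2ccc(C3CCCCC3)cc2)cc1` carries cyclohexyl, and in this assay compound 3 reaches only a limit of the assay, > 1000 nM. Compound 3 thus stands at the limit of > 1000 nM in this assay, at which 1 of the 3 values shown sits. The steps between the three are all modest: a 1.5-fold lower number from compound 1 to compound 2 (0.18 log units; within the scatter); an at least 1.1-fold higher number from compound 1 to compound 3 (0.06 log units; that floor lies within the scatter); an at least 1.7-fold higher number from compound 2 to compound 3 (0.23 log units; that floor lies within the scatter). Compound 4 `O=C1NCCN1c1ccc(S(=O)(=O)Nc2ccc(Br)cc2)cc1` is not yet measured and differs from compound 3 in one place: bromo in place of cyclohexyl on an aromatic carbon. The two steps that end in cyclohexyl bear on this change, and both were only floors within the scatter, so moving back to a small group is expected to give, if anything, a somewhat lower number. Compound 4 is therefore expected to land near 700 nM, within a range from 300 nM to 2000 nM. That amounts to an expected at least 1.4-fold lower number from compound 3 to compound 4 (0.15 log units; that floor lies within the scatter).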

Compound 4, half-maximal inhibitory concentration: 130 nM
The estimate for compound 4 lay 5.4-fold (0.73 log units) above the measured number, and the stated range ends above it.
By their numbers in this assay, from the lowest: compound 4; then compounds 2 and 1 (each within the scatter of the next). At a limit, above all of these: compound 3.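

Within the data shown here, at this position, on an aromatic carbon para to a large group, the choice of group now clearly matters in this assay: the earlier steps all stayed within the scatter, whereas bromo brings a 4.5-fold lower number from compound 2 to compound 4 (0.65 log units; beyond the scatter) and a 6.7-fold lower number from compound 1 to compound 4 (0.83 log units; beyond the scatter). Replacing cyclohexyl, with its ring of carbon, by the single atom of bromo brings an at least 7.6-fold lower number from compound 3 to compound 4 (0.88 log units; beyond the scatter), which makes compound 4 the strongest of the four, though this step is only a floor. Compound 3 gives no exact number, only a limit of the assay: the limit of > 1000 nM in this assay, at which 1 of the 4 values shown sits.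

From the compounds shown here alone, whether chloro, fluoro or an amine at this position would match bromo remains open. Going by these compounds, the full size of the step from cyclohexyl to bromo also remains open.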